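A few compounds are considered here, and "the series" means these few. Any claim that something is new, unique, unknown or untested is made for them only; others in the source may bear on it.

Of the compounds shown here, three of one shared core have been tested in an assay on isolated protein for agonist activity at Bile acid receptor (Homo sapiens), read by AlphaScreen, with a stated time of 30 min; on this read-out higher numbers stand for an effect only at larger amounts of compound and lower numbers for an effect already at smaller amounts. Compound 1 `Cc1ccccc1-n1nc(C)c2c1NC(=O)[C@H](C)S[C@@H]2c1ccc(-c2cccc(C(=O)O)c2)cc1` carries a carboxy group on its outer aromatic ring; in this assay compound 1 is recorded as "not active" (no number reported), so no number stands for it, and it is one of two compounds here without a single number. Compound 3 `Cc1ccccc1-n1nc(C)c2c1NC(=O)[C@H](C)S[C@@H]2c1ccc(OCc2ccccc2)cc1` is likewise recorded as "not active" (no number reported). Going by the values given here, compound 2 `COc1ccc(Oc2ccc([C@H]3S[C@@H](C)C(=O)Nc4c3c(C)nn4-c3ccccc3C)cc2)cc1` is the only one with a number: in this assay compound 2 gives 2200 nM.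

Compound 4 `Cc1ccccc1-n1nc(C)c2c1NC(=O)[C@H](C)S[C@@H]2c1ccc(-c2ccccc2)cc1` has not yet been measured. It differs from compound 1 in one place: hydrogen in place of carboxy on an aromatic carbon. Among the compounds with values here, no measured pair in this set matches that change, so its size and direction cannot be read from a measured step; the outcome for compound 4 rests only on the picture above, in which compound 2 shows a measurable effect and two other members show none. Compound 4 is expected to land near 6000 nM, within a broad range from 1500 nM to 25000 nM, with a real chance that no number is returned.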

Compound 4, half-maximal effective concentration: 990 nM
Beside the measured number, compound 4's estimate is 6.1-fold (0.78 log units) above it, and the stated range ends above it.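

In this assay compound 1 gives "not active" (no number reported) and compound 4 gives 990 nM once hydrogen replaces the carboxy group, so the change from 3-carboxyphenyl to phenyl separates a compound without a number from one with a number. The size of that change cannot be read as a step, as compound 1 has no number to start from. The outer group also shifts a measured value, with phenyl in place of 4-methoxyphenoxy giving a 2.2-fold lower number from compound 2 to compound 4 (0.35 log units; beyond the scatter) in the same test. Nothing measured here explains either result.

From the compounds shown here alone, whether an amine or a hydroxy group in place of the carboxy group would also give a number remains open. The compounds shown also leave open how a methyl or a methoxy group on the outer phenyl ring of compound 4 would shift its value.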